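This account rests on a few compounds, and the source may have more. Where it says the series, first, only, none or still open, it means among the compounds named here.

Measured in a physicochemical assay for lipophilicity; on this read-out lower numbers stand for lower lipophilicity and higher numbers for higher lipophilicity:
- compound 1 `CC#CCn1c(N2CCC[C@@H](N)C2)cc(=O)n(Cc2c(Br)c(Br)c(OC)c(OC)c2Br)c1=O`: 4.04
- compound 2 `COc1cc(Cn2c(=O)cc(N3CCC[C@@H](N)C3)n(Cc3cc(F)ccc3C#N)c2=O)c(Br)c(Br)c1OC`: 4.32

Compound 2, at 4.32, and compound 1, at 4.04, lie within the usual scatter of each other, so neither stands clearly apart. Compound 3 `COc1c(Br)c(Br)c(Cn2c(=O)cc(N3CCC[C@@H](N)C3)n(Cc3cc(F)ccc3C#N)c2=O)c(Br)c1OC` differs from compound 2 by bromo in place of hydrogen on an aromatic carbon. For the measured compounds named here, no measured pair isolates this change, so the expectation rests on the structural change alone. A moderate rise beyond the scatter is expected in this assay, and the estimated step is a number 0.48 log units higher from compound 2 to compound 3 (beyond the scatter). For compound 3 the expected value is 4.8, within an estimated range of 4.4 to 5.2.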

Compound 3, partition coefficient: 5.15
For compound 3 the middle estimate is 0.35 log units below the measured one, within the range that was stated.
By their numbers in this assay, from the lowest: compounds 1 and 2 (each within the scatter of the next); then compound 3.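

In this assay the change of hydrogen to bromo on this aromatic carbon, ortho to a methoxy group, gives a number 0.83 log units higher from compound 2 to compound 3 (beyond the scatter) and so clearly registers at this position. With that bromo present, 2-cyano-5-fluorophenyl in place of prop-1-yn-1-yl gives a number 1.11 log units higher from compound 1 to compound 3 (beyond the scatter) as a separate single change. Nothing measured here accounts for either step. Going by these compounds, whether a chloro, methyl or amine at this carbon would give a similar step stays open, as does whether bromo gives the same step alongside prop-1-yn-1-yl.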